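The source may report more compounds than this note shows. Statements on the series, on what has been measured and on what is new or still open speak of the compounds shown alone.

Measured compounds in a functional assay on VCaP cells (Homo sapiens) for antiproliferative activity, read by CCK-8 assay, with a stated time of 6 days; a higher number here means a weaker inhibitor, a lower number a stronger inhibitor:

Compound 1 `CCN(c1ccc(C#N)c(Cl)c1)c1cc(-n2ccnc2)ccc1C` gives > 30000 nM, which is a limit of this assay, not a number.
Compound 2 `CCN(c1ccc(C#N)c(Cl)c1)c1cc(-c2cn[nH]c2)ccc1C` has no result reported; its entry reads "not determined" (no result reported).
Compound 3 `CCN(c1ccc(C#N)c(Cl)c1)c1cc(-c2c[nH]nc2C)ccc1C` gives 3190 nM.

For the measured compounds named here, compound 3 thus carries the only number in this assay; compound 1 sits at the limit of > 30000 nM in this assay, at which 1 of the 3 values shown sits, and compound 2 has no value. Going by the values given here, the one measured step, an at least 9.4-fold lower number from compound 1 to compound 3 (0.97 log units; beyond the scatter), is at least modest and beyond the scatter, though its true size is open since it starts from a limit.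

Compound 4 `CCN(c1ccc(C#N)c(Cl)c1)c1cc(-c2ccc(F)nc2)ccc1C` differs from compound 3 by 6-fluoropyridin-3-yl in place of 3-methyl-1H-pyrazol-4-yl on an aromatic carbon. This change bears only loosely on the measured step: both compound 1 and compound 4 lack the hydrogen-bond donor of compound 3, but the ring that enters in compound 4 is six-membered and the comparison from compound 1 to compound 3 does not isolate the donor. The expectation for compound 4 is therefore a weaker result than compound 3, with wide uncertainty, and the step is estimated as a 3.1-fold higher number from compound 3 to compound 4 (0.50 log units; beyond the scatter). Compound 4 is expected at about 10000 nM, in a range from 2500 nM to 40000 nM.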

Compound 4, half-maximal inhibitory concentration: > 30000 nM
Compound 4: only a limit was reported (the forecaster's own chance of this, stated with the estimate: 35%); middle value at least 3.0-fold (0.47 log units) from the limit.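

At this position, para to a methyl group, 6-fluoropyridin-3-yl does not hold the activity of 3-methyl-1H-pyrazol-4-yl in this assay: the change gives an at least 9.4-fold higher number from compound 3 to compound 4 (0.97 log units; beyond the scatter). The end of that step, at compound 4, is a limit of the assay and not a number, so its true size is open. Compound 1 and compound 4 share that limit, so the step between them cannot be read, and two different rings in place of 3-methyl-1H-pyrazol-4-yl now end at the same point: the limit of > 30000 nM in this assay, at which 2 of the 4 values shown sit.

The change to compound 4 alters ring size, hetero atoms and the hydrogen-bond donor together, and compound 2 has no result reported, so neither the donor nor the methyl group of compound 3 is isolated. Also open, going by these compounds, is how an amine or a carboxylic acid on this aromatic carbon would compare with compound 3.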